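A Two-Ring Carbon Group in Place of Bromine

This account rests on a few compounds, and the source may have more. Where it says the series, first, only, none or still open, it means among the compounds named here.

Going by the values given here, compound 1 `CC(C(=O)NCc1ccc(C(F)(F)F)nc1Br)c1ccc(NS(C)(=O)=O)c(F)c1` gives 169 nM in an assay on CHO cells for antagonist activity at transient receptor potential cation channel subfamily V member 1 (Homo sapiens), read by FLIPR and calcium flux (on this read-out lower numbers stand for stronger inhibition and higher numbers for weaker inhibition), the highest of the two numbers measured so far. Among the compounds with values here, compound 2 `CC(C(=O)NCc1ccc(C(F)(F)F)nc1CCC(C)(C)C)c1ccc(NS(C)(=O)=O)c(F)c1` gives 0.6 nM in this assay, and the only measured step, a 280-fold lower number from compound 1 to compound 2 (2.45 log units; beyond the scatter), shows how strongly a saturated carbon group at this carbon can lower the number. Compound 3 `CC(C(=O)NCc1ccc(C(F)(F)F)nc1C1CC2CCC1C2)c1ccc(NS(C)(=O)=O)c(F)c1` differs from compound 1 by a group of 7 heavy atoms (7 carbon; 2 five-membered non-aromatic rings of carbon only) in place of one bromine atom, on an aromatic carbon. The entering group resembles that of compound 2 in being saturated carbon of similar size, so a large lowering is expected for compound 3, an 85-fold lower number from compound 1 to compound 3 (1.93 log units; beyond the scatter). Compound 3 is estimated at 2 nM, within 0.4 nM to 10 nM.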

Compound 3, inhibition constant: 1.5 nM
Estimate against measurement, compound 3: 1.3-fold (0.12 log units) above; low and high end bracket the measured number.
By their numbers in this assay, from the lowest: compound 2; then compound 3; then compound 1.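

In this assay, the two-ring carbon group also gives a large lowering (a 110-fold lower number from compound 1 to compound 3 (2.05 log units; beyond the scatter)), so at this aromatic carbon next to the ring nitrogen, the effect is not confined to the open-chain 3,3-dimethylbutyl group. Against that chain, the two-ring group gives only a modest change (a 2.5-fold higher number from compound 2 to compound 3 (0.40 log units; beyond the scatter)). No measurement available here explains either step.

The compounds shown leave open whether a shorter chain such as ethyl would also give a low number at this carbon. They also leave open whether an amine or a morpholine ring would do so.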